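This account rests on a few compounds, and the source may have more. Where it says the series, first, only, none or still open, it means among the compounds named here.

Compound 3 `CCNC(=O)c1noc(-c2cc(C(C)C)c(O)cc2O)c1-c1cc(CN(C)C)no1` gives 92 nM in a functional assay on HCT-116 cells (Homo sapiens) for inhibition (a higher number here means a weaker inhibitor, a lower number a stronger inhibitor), and stands second highest of the three numbers: compound 1 `CCNC(=O)c1noc(-c2cc(C(C)C)c(O)cc2O)c1-c1cc(CO)no1` gives 13 nM and compound 2 `CCNC(=O)c1noc(-c2cc(C(C)C)c(O)cc2O)c1-c1cc(COCC(=O)OC)no1` gives 262 nM. Compound 4 `CCNC(=O)c1noc(-c2cc(C(C)C)c(O)cc2O)c1-c1cc(C(=O)NC)no1` differs from compound 3 by methylcarbamoyl in place of (dimethylamino)methyl on an aromatic carbon. All three measured steps alter this same group: a 7.1-fold higher number from compound 1 to compound 3 (0.85 log units; beyond the scatter), a 20-fold higher number from compound 1 to compound 2 (1.30 log units; beyond the scatter) and a 2.8-fold lower number from compound 2 to compound 3 (0.45 log units; beyond the scatter). Replacing the hydroxymethyl of compound 1 raised the number in both cases, so this position clearly matters. Compound 4 is expected to improve modestly because a 2.8-fold lower number from compound 2 to compound 3 (0.45 log units; beyond the scatter) and a 7.1-fold higher number from compound 1 to compound 3 (0.85 log units; beyond the scatter) leave room below compound 3, giving an estimated step of a 2.0-fold lower number from compound 3 to compound 4 (0.31 log units; beyond the scatter). The estimate for compound 4 is therefore 45 nM, within a range from 12 nM to 170 nM.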

Compound 4, half-maximal inhibitory concentration: 124 nM
Beside the measured number, compound 4's estimate is 2.8-fold (0.44 log units) below it; the measured number falls inside the stated range.
By their numbers in this assay, from the lowest: compound 1; then compounds 3 and 4 (each within the scatter of the next); then compound 2.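

In this assay, methylcarbamoyl and (dimethylamino)methyl cannot be told apart at this position (a 1.3-fold higher number from compound 3 to compound 4 (0.13 log units; within the scatter)), even though only methylcarbamoyl has a hydrogen-bond donor. Methylcarbamoyl gives a lower number than the ((methoxycarbonyl)methoxy)methyl group (a 2.1-fold lower number from compound 2 to compound 4 (0.32 log units; beyond the scatter)) but remains well above hydroxymethyl (a 9.5-fold higher number from compound 1 to compound 4 (0.98 log units; beyond the scatter)), so hydroxymethyl keeps the lowest number among the four compounds. Nothing available explains this order. As far as these compounds go, it remains open whether a carboxylic acid, an aminomethyl group or a longer hydroxyalkyl chain at this position would match or lower the number of compound 1.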